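Chloro to hydroxy on the aryl ring of the shared core

This account rests on a few compounds, and the source may have more. Where it says the series, first, only, none or still open, it means among the compounds named here.

For the measured compounds named here, compound 2 `CN1CCN(c2nc(-c3ccc(Cl)cc3)nc3[nH]cnc23)CC1` gives 6.2% in an assay on cells for displacement of a labelled ligand from adenosine receptor A2b (Homo sapiens), read by scintillation counting and radioligand binding, with a stated time of 30 min, tested at 10 uM (on this read-out lower numbers stand for less inhibition and higher numbers for more inhibition at the one concentration tested (going by the name of the read-out)), the lower of the two numbers measured so far. Going by the values given here, compound 1 `CN1CCN(c2nc(-c3cccc(Cl)c3)nc3[nH]cnc23)CC1`, differing only in where the chloro sits, gives 29.9%; the step of a number 23.7 percentage points lower from compound 1 to compound 2 (beyond the scatter) is the single measured step. Compound 3 `CN1CCN(c2nc(-c3ccc(O)cc3)nc3[nH]cnc23)CC1` is not yet measured. It differs from compound 2 by hydroxy in place of chloro on an aromatic carbon. Among the compounds with values here, no measured pair exchanges chloro for hydroxy, so the one available step, a change of position only, does not bear directly on this replacement; it shows merely that compound 2 sits at the low end. Within the data shown here, with no step to lean on, compound 3 is expected to stay low, with a step of about a number 3.8 percentage points higher from compound 2 to compound 3 (within the scatter), near or within the scatter. The estimate for compound 3 is therefore 10%, in the range -5% to 30%.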

Compound 3, a percentage reported as inhibition, at one concentration (the size of the read-out at that concentration, not a potency): 53%
For compound 3 the middle estimate is 43 percentage points below the measured one; measured number outside the range, above it.
By their numbers in this assay, from the lowest: compound 2; then compound 1; then compound 3.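

In this assay, hydroxy in place of chloro para to a large group gives a large rise (a number 46.8 percentage points higher from compound 2 to compound 3 (beyond the scatter)), so the low number at this position belongs to the chloro compound and not to the position as such. The 4-hydroxyphenyl group also stands clear of the 3-chlorophenyl group (a number 23.1 percentage points higher from compound 1 to compound 3 (beyond the scatter)), which puts compound 3 highest of the three and shows that the choice of group can move the read-out at least as far as moving a chloro does. No evidence at hand accounts for this rise.

Open, on these data alone, is whether the rise is particular to hydroxy or also appears with an amine or a methoxy on the same aromatic carbon. Also open, as far as these compounds go, is whether hydroxy at the place the chloro occupies in compound 1 would keep or lose the higher number.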